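The source may hold more compounds than are shown below. What is called first, only, known or untested is meant among the compounds shown, and "the series" means these compounds.

In an ADME assay on a cell-free system (plasma, Rattus norvegicus) for metabolic stability, read by LC-MS, with a stated time of 60 min, tested at 100 uM (a higher number here means that more of the compound is left, a lower number that less of the compound is left), compound 1 `Cc1cc(C(=O)O)ccc1OCCCCOc1ccc(C(=O)CC(C)C)c(O)c1C` gives 100% as the second highest of three numbers. Compound 3 `Cc1c(OCCCCOc2ccc(F)c(C(=O)O)c2)ccc(C(=O)CC(C)(C)C)c1O` gives 83% and compound 2 `Cc1c(OCCCCOc2ccc(C(=O)O)cc2Cl)ccc(C(=O)CC2CCCC2)c1O` gives 120% with both gaps to compound 1 beyond the usual scatter. Compound 4 `Cc1c(OCCCCOc2ccc(C(=O)O)cc2)ccc(C(=O)CC(C)C)c1O` has not been measured yet and differs from compound 1 in one place: hydrogen in place of methyl on an aromatic carbon with hydrogen in place of methyl on an aromatic carbon, turning 4-carboxy-2-methylphenyl into 4-carboxyphenyl. For the measured compounds named here, no measured pair shows this change alone. Compound 1 at 100% is therefore the starting point, and no step beyond the scatter is expected in this assay for so small a change. The estimated step is a number 2 percentage points lower from compound 1 to compound 4 (within the scatter) in this reading. The estimate for compound 4 is 98% with an expected range from 80% to 115% around it.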

Compound 4, percent of the compound remaining: 95%
Compound 4: the middle estimate sits 3 percentage points above what was measured; low and high end bracket the measured number.
By their numbers in this assay, from the lowest: compound 3; then compounds 4 and 1 (each within the scatter of the next); then compound 2.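

In this assay, hydrogen in place of methyl, which turns 4-carboxy-2-methylphenyl into 4-carboxyphenyl, gives a number 5 percentage points lower from compound 1 to compound 4 (within the scatter). This is the only pair shown that differs in this one place, and it shows that compound 4 keeps a reading within the scatter of compound 1 without this methyl. No separate measurement bears on why this is so. As far as these compounds go, whether an ethyl group or an amine at this place would also stay within the scatter remains open. So does whether this change behaves the same way on the other compounds, as only this one pair carries it.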